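The compounds below may be only part of what the source reports. "The series", "measured", "known", "first", "only" and "open" are said of these compounds alone.

Compound 1 `COc1cc(OC)c2c(=O)cc(/C=C/c3ccc(Cl)cc3)oc2c1` is the reference point of the series. In a functional assay on PC-3 cells (Homo sapiens) for antiproliferative activity, read by MTT assay, with a stated time of 12 h (a higher number here means a weaker inhibitor, a lower number a stronger inhibitor), compound 1 gives > 40000 nM, which is a limit of the assay and not a measured number. Compound 2 `COc1cc(OC)c2c(=O)cc(/C=C/c3ccc(C(F)(F)F)cc3)oc2c1` carries trifluoromethyl in place of chloro on an aromatic carbon. In this assay compound 2 gives > 40000 nM, again a limit rather than a number. The step that the two limits leave unreadable from compound 1 to compound 2 therefore cannot be read in size or direction, since both ends sit at the same limit; this is the whole of the evidence so far, summarised in the limit of > 40000 nM in this assay, at which 2 of the 2 values shown sit.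

Compound 3 `COc1ccc(/C=C/c2cc(=O)c3c(OC)cc(OC)cc3o2)cc1` is the next member to be measured. It differs from compound 1 by methoxy in place of chloro on an aromatic carbon. Going by the values given here, no measured step in this assay bears on this change: the only step is the unreadable one from compound 1 to compound 2, and it gives no size and no direction to carry over. With compound 1 at a limit, the expectation for compound 3 is set by the step that the limit leaves unreadable from compound 1 to compound 3, which is taken as none beyond the scatter.

The estimate for compound 3 in this assay is 50000 nM, with a range from 15000 nM to 200000 nM.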

Compound 3, half-maximal inhibitory concentration: > 40000 nM
Compound 3 gave a limit, no number; the forecaster's own chance of this, stated with the estimate: 70%; the middle value lies beyond the limit too.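

In this assay compound 3 gives > 40000 nM as a limit and not a number. The steps joining compound 3 to compound 1 and compound 2 cannot be read in size or direction, and the series stands as follows: the limit of > 40000 nM in this assay, at which 3 of the 3 values shown sit.

The compounds shown leave open whether these three differ at all in this assay, and how large any such difference would be.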